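A few compounds are considered here, and "the series" means these few. Any claim that something is new, unique, unknown or untested is made for them only; others in the source may bear on it.

The study opens with three compounds that all test beyond the reach of a toxicity assay on HepG2 cells (Homo sapiens) for inhibition, read by CellTiter-Glo, with a stated time of 48 h; a lower number here means a stronger inhibitor, a higher number a weaker inhibitor. Compound 1 `COc1ccc2nc(C)cc(OC(C)(C)C(=O)Nc3cc(C)cc(C)c3)c2c1` gives > 100000 nM, which is a limit of the assay rather than a number. Compound 2 `COc1ccc2nc(C)cc(NC(=O)C(=O)Nc3cc(C)cc(C)c3)c2c1` likewise gives > 100000 nM, again a limit. Compound 3 `COc1ccc(NC(=O)COc2cc(C)nc3ccc(OC)cc23)cc1` gives > 100000 nM, also a limit. Compound 3 therefore stands at the limit of > 100000 nM in this assay, at which 3 of the 3 values shown sit, with nothing to set it apart from the other two. Compound 4 `COc1ccc2nc(C)cc(OCC(=O)Nc3c(C)cncc3C)c2c1` has not yet been measured. It differs from compound 3 by 3,5-dimethylpyridin-4-yl in place of 4-methoxyphenyl on an amide-type nitrogen. Within the data shown here, with no measured step to draw on and all three values sitting at a limit, no move beyond the usual scatter in either direction is expected; the expected step is a number no higher from compound 3 to compound 4 (the limit leaves the size open). Compound 4 is accordingly estimated at 100000 nM, between 50000 nM and 200000 nM.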

Compound 4, half-maximal inhibitory concentration: 12600 nM
For compound 4 the middle estimate is 7.9-fold (0.90 log units) above the measured one, outside the stated range (below it).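

Replacing 4-methoxyphenyl with 3,5-dimethylpyridin-4-yl on the amide-type nitrogen gives an at least 7.9-fold lower number from compound 3 to compound 4 (0.89 log units; beyond the scatter) in this assay, so a change at this place alone can bring a reading within the range of the assay. The size of the step remains a minimum, as compound 3 sits at a limit. Compound 4 is the only compound shown with a measured number, and the others remain at the limit: the limit of > 100000 nM in this assay, at which 3 of the 4 values shown sit.

The ring nitrogen and the two methyl groups enter together, so the compounds shown do not separate their contributions. Also open, going by these compounds, is how a pyridin-4-yl group without methyl groups, or a phenyl group carrying a carboxylic acid, would read at this place.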